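The source may report more compounds than this note shows. Statements on the series, on what has been measured and on what is new or still open speak of the compounds shown alone.

In a functional assay on T47D cells (Homo sapiens) for cytotoxicity, read by CCK-8 assay (on this read-out higher numbers stand for weaker inhibition and lower numbers for stronger inhibition), compound 2 `Oc1cccc(-c2cc(-c3ccco3)cc(-c3cccc(O)c3)n2)c1` gives 3520 nM, the only number so far shown. Compound 1 `Oc1ccc(-c2cc(-c3ccco3)cc(-c3ccccc3O)n2)cc1` stays at the assay limit of > 50000 nM. Compound 3 `Oc1ccc(-c2cc(-c3ccco3)cc(-c3cccc(O)c3)n2)cc1` carries 4-hydroxyphenyl in place of 3-hydroxyphenyl on an aromatic carbon. Within the data shown here, no step between measured compounds is known, so the size of this change rests on what the pair shows. Compound 1, which carries no 3-hydroxyphenyl group, sits at the limit of > 50000 nM in this assay, at which 1 of the 2 values shown sits. The step is therefore expected to weaken inhibition, roughly by a 2.8-fold higher number from compound 2 to compound 3 (0.45 log units; beyond the scatter). Compound 3 is estimated in this assay at 10000 nM, with a range from 3000 nM to 50000 nM.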

Compound 3, half-maximal inhibitory concentration: 1280 nM
Compound 3: middle estimate off by 7.8-fold (0.89 log units), on the high side; the whole stated range lies above it.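

In this assay, with the atoms unchanged, moving the hydroxyl of the aryl group next to the ring nitrogen to give 4-hydroxyphenyl strengthens inhibition, with a 2.8-fold lower number from compound 2 to compound 3 (0.44 log units; beyond the scatter). With 4-hydroxyphenyl kept, 3-hydroxyphenyl in place of 2-hydroxyphenyl gives a much larger change, with an at least 39-fold lower number from compound 1 to compound 3 (1.59 log units; beyond the scatter). Compound 1 stands at a limit and not at a number: the limit of > 50000 nM in this assay, at which 1 of the 3 values shown sits.

From the compounds shown here alone, it remains open whether a methoxy group or an amine in place of either hydroxyl would keep this inhibition. Going by these compounds, the role of furan-2-yl also remains open, as that group is the same throughout.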